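The source may hold more compounds than are shown below. What is called first, only, known or untested is meant among the compounds shown, and "the series" means these compounds.

Measured so far:
compound 1, `Cc1nc(C(NC(=O)C(=O)Nc2ccc(F)c(F)c2)C2CCCCN2)sc1CO`, with > 87000 nM
compound 2, `Cc1nc(C(NC(=O)C(=O)Nc2ccc(F)cc2)C2CCCCN2)sc1CO`, with > 90000 nM
compound 3, `Cc1nc(C(NC(=O)C(=O)Nc2ccc(F)cc2)C2CCCCN2)sc1CCO`, with > 88000 nM

All three values are limits of the assay, not numbers. In an ADME assay on TZM-b1 cells (Homo sapiens) for cytotoxicity, read by XTT assay, with a stated time of 3 days (on this read-out lower numbers stand for higher toxicity in this test and higher numbers for lower toxicity in this test), compound 1 gives > 87000 nM, a limit. In this assay compound 2 gives > 90000 nM, also a limit. In this assay compound 3 gives > 88000 nM, again a limit.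

From compound 2 to compound 1 the change is fluoro in place of hydrogen on an aromatic carbon, and the step is a step that the two limits leave unreadable from compound 2 to compound 1. The two cores differ as hydroxymethyl in place of hydroxy on a saturated chain carbon bound to an aromatic carbon, with the step that the two limits leave unreadable from compound 2 to compound 3.

Compound 4, `Cc1nc(C(NC(=O)C(=O)Nc2ccc(F)cc2F)C2CCCCN2)sc1CCO`, has not yet been measured. It differs from compound 3 by fluoro in place of hydrogen on an aromatic carbon. This is the same kind of change as from compound 2 to compound 1, though not the same: there the fluoro enters ortho to a fluoro group and meta to a large group, here ortho to a large group and meta to a fluoro group.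

Compound 4 is expected to show a step that the limit leaves unreadable from compound 3 to compound 4 in this assay, beside the earlier one. That expectation rests on (the limit of > 87000 nM in this assay, at which 1 of the 3 values shown sits), the limit of > 88000 nM in this assay, at which 1 of the 3 values shown sits, and (the limit of > 90000 nM in this assay, at which 1 of the 3 values shown sits), at which every measured value sits. Compound 4 is therefore estimated at 90000 nM, between 50000 nM and 300000 nM.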

Compound 4, half-maximal cytotoxic concentration: > 84000 nM
Compound 4: no number, only a limit (the forecaster's own chance of this, stated with the estimate: 85%); the middle value does not contradict the limit.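

In this assay compound 4 gives > 84000 nM, which is a limit of the assay and not a number. Among the compounds shown here, compound 3 is also known only as a limit, and no step from it to compound 4 can be read. The compounds shown leave open at what concentration any of them would become toxic to these cells, and whether the added fluoro changes that concentration.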